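The source may report more compounds than this note shows. Statements on the series, on what has been measured and on what is new or still open speak of the compounds shown alone.

Compound 1 `CCc1cc(Nc2nc(N[C@@H](C)c3ccc(F)cn3)nc3cccc(C)c23)n[nH]1` is one of two compounds with a number in an assay on KMS-11 cells for binding affinity to G protein-coupled receptor kinase 6 (Homo sapiens), with a stated time of 2.5 h; on this read-out higher numbers stand for weaker inhibition and lower numbers for stronger inhibition. In this assay compound 1 gives 610 nM, the lower of the two values. Compound 2 `CCc1cc(Nc2nc(NCc3ccc(Cl)cc3)nc3cccc(OC)c23)n[nH]1` gives 2000 nM in this assay, a higher number than that of compound 1, and the gap between the two lies beyond the usual scatter. For the measured compounds named here, no single-point step between them is available, since compound 2 differs from compound 1 in more than one place.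

Compound 3 `CCc1cc(Nc2nc(NCc3ccc(Cl)cc3OC)nc3cccc(C)c23)n[nH]1` has not been measured in this assay. It differs from compound 1 in one place: 4-chloro-2-methoxybenzyl in place of 1-(5-fluoropyridin-2-yl)ethyl on a nitrogen on an aromatic ring. The change removes the defined stereocentre and the ring nitrogen while bringing in a chlorine and a methoxy group. Going by the values given here, with no measured step of this kind to draw on, the direction must be judged from the values of compound 1 and compound 2 alone, and a move toward a weaker number is expected. The expected step from compound 1 to compound 3 is a 2.5-fold higher number from compound 1 to compound 3 (0.39 log units; beyond the scatter). Compound 3 is therefore estimated to give about 1500 nM in this assay, with a likely range from 500 nM to 5000 nM.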

Compound 3, half-maximal inhibitory concentration: 170 nM
Compound 3: middle estimate off by 8.8-fold (0.95 log units), on the high side; the measured number lies below the stated range.
By their numbers in this assay, from the lowest: compound 3; then compound 1; then compound 2.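

Replacing 1-(5-fluoropyridin-2-yl)ethyl with 4-chloro-2-methoxybenzyl on this nitrogen gives a 3.6-fold lower number from compound 1 to compound 3 (0.55 log units; beyond the scatter) in this assay and so marks this position as one where the attached group shifts the number beyond the scatter. The change shows that neither the defined stereocentre nor the ring nitrogen of compound 1 is needed for a lower number, since compound 3 has neither. No evidence bears on why the number falls.

The step exchanges the whole group at once, so the shares of the chlorine, the methoxy group, the stereocentre and the ring nitrogen remain unseparated. Also open, on these data alone, is how a 2-methoxybenzyl group without the chlorine, or a benzyl group carrying an amine or a carboxylic acid, would compare with compound 3 at this position.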